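Changing the Aryl Group on a Hydrazone Cytotoxicity Series

The compounds below may be only part of what the source reports. "The series", "measured", "known", "first", "only" and "open" are said of these compounds alone.

Compound 1 `O=C(CSc1nnc(-c2ccncc2)o1)N/N=C/c1ccccc1F` gives 16000 nM in a functional assay on HepG2 cells (Homo sapiens) for cytotoxicity, read by MTT assay, with a stated time of 48 h; on this read-out higher numbers stand for weaker inhibition and lower numbers for stronger inhibition.
Compound 2 `O=C(CSc1nnc(-c2ccncc2)o1)N/N=C/c1cc(Cl)cc(Cl)c1O` gives 3260 nM in this assay.

Compound 2 has the lowest number of the two measured, with a 4.9-fold lower number from compound 1 to compound 2 (0.69 log units; beyond the scatter). Compound 3 `COc1cc(/C=N/NC(=O)CSc2nnc(-c3ccncc3)o2)ccc1O` is not yet measured; it differs from compound 2 by 4-hydroxy-3-methoxyphenyl in place of 3,5-dichloro-2-hydroxyphenyl on a carbon with a double bond to nitrogen. For the measured compounds named here, only the step from compound 1 to compound 2 bears on this change, and it shows that replacing the aryl group can move the number beyond the scatter. The expectation for compound 3 is a weakening, with a 3.1-fold higher number from compound 2 to compound 3 (0.49 log units; beyond the scatter). Compound 3 is therefore estimated at 10000 nM, within a range from 3000 nM to 40000 nM.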

Compound 3, half-maximal inhibitory concentration: 2920 nM
For compound 3 the middle estimate is 3.4-fold (0.53 log units) above the measured one; the whole stated range lies above it.
By their numbers in this assay, from the lowest: compounds 3 and 2 (each within the scatter of the next); then compound 1.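

In this assay there is a 1.1-fold lower number from compound 2 to compound 3 (0.05 log units; within the scatter) at the carbon with a double bond to nitrogen, so a number at this level does not require the two chlorine atoms of compound 2. Against the 2-fluorophenyl group there is also a 5.5-fold lower number from compound 1 to compound 3 (0.74 log units; beyond the scatter) on this read-out, so a chlorine-free aryl group can also clear the scatter around compound 1. No measured evidence explains why these aryl groups give these numbers.

From the compounds shown here alone, compound 2 and compound 3 both carry a hydroxy group, and whether it matters stays open. A plain phenyl or a 4-aminophenyl group at this place would help to test that.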